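Removing the ring hydroxyl from compound 1

The source may report more compounds than this note shows. Statements on the series, on what has been measured and on what is new or still open speak of the compounds shown alone.

Compound 1 `COC(=O)[C@]1(Cc2ccc3c(c2)C[C@@H](O)C(C)(C)O3)OC(=O)C(O)=C1c1ccc(O)cc1` is the reference point of the series. Among the measured compounds shown here, in an assay on isolated protein for inhibition of Alpha glucosidase (Homo sapiens), read by spectrophotometry, with stated times of 5 min and 15 min (a higher number here means a weaker inhibitor, a lower number a stronger inhibitor), compound 1 gives 110000 nM, and this is the only number available in this assay. Compound 2 `COC(=O)[C@]1(Cc2ccc3c(c2)C[C@H](C(C)(C)O)O3)OC(=O)C(O)=C1c1ccc(O)cc1` is the second member measured, and in this assay compound 2 returns > 400000 nM, which is a limit of the assay and not a number. For the measured compounds named here, compound 1 therefore stands as the sole numeric value, the other result being (the limit of > 400000 nM in this assay, at which 1 of the 2 values shown sits). Going by the values given here, no two measured compounds differ in a single place, so no measured step is available to calibrate against.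

Compound 3 `COC(=O)[C@]1(Cc2ccc3c(c2)CCC(C)(C)O3)OC(=O)C(O)=C1c1ccc(O)cc1` differs from compound 1 by hydrogen in place of hydroxy on a saturated ring carbon. With one number and one limit, no trend is established, and the change is confined to the hydroxy group. The step from compound 1 to compound 3 is expected to be modest, most likely within the scatter, with a slight lean toward weaker inhibition, which as an estimate amounts to a 1.4-fold higher number from compound 1 to compound 3 (0.13 log units; within the scatter). Compound 3 is accordingly estimated at 150000 nM, with a range from 60000 nM to 400000 nM.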

Compound 3, half-maximal inhibitory concentration: 47300 nM
For compound 3 the middle estimate is 3.2-fold (0.50 log units) above the measured one, outside the stated range (below it).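

Replacing the hydroxy with hydrogen on this saturated ring carbon gives, in this assay, a 2.3-fold lower number from compound 1 to compound 3 (0.37 log units; beyond the scatter), a modest step toward stronger inhibition. Among the compounds shown here, this is the first measured comparison between compounds that differ in one place, and it shows that the hydroxy at this position, two ring bonds from the ring oxygen, is not required for the inhibition seen with compound 1, since the compound without it inhibits more strongly. No measurement at hand bears on the reason for this step.

A single step at a single position cannot show whether the gain follows from losing the hydroxy as such or whether other groups on the same ring carbon would be tolerated as well, and a methoxy, an amine or a fluorine there would help to separate these readings. Also open, on these data alone, is whether the two methyl groups on the neighbouring ring atom matter to this step, which a comparison with hydrogen in their place, on the core of compound 3, could address.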